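The source may report more compounds than this note shows. Statements on the series, on what has been measured and on what is new or still open speak of the compounds shown alone.

Measured so far:
- compound 1, `CNC(=O)/C=C/c1ccncc1-c1ccc2cccnc2c1`: 1760 nM
- compound 2, `O=C(/C=C/c1ccncc1-c1ccc2[nH]ccc2c1)N1CCOCC1`: 190 nM
- compound 3, `CCOC(=O)/C=C/c1ccncc1-c1ccc2ccccc2c1`: 53.3 nM

All three numbers come from an assay on a protein complex for inhibition of CDK8/Cyclin C (Homo sapiens), with a stated time of 1 h; a lower number here means a stronger inhibitor, a higher number a weaker inhibitor. Among them compound 2 stands second highest: compound 3 lies beyond the scatter with its lower number, and compound 1 lies further away still with its higher number. No two of these compounds differ in one place only, so nothing here isolates the effect of a single change.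

Compound 4, `O=C(O)/C=C/c1ccncc1-c1ccc2[nH]ccc2c1`, has not been measured. It differs from compound 2 in one place: hydroxy in place of morpholin-4-yl on a carbonyl carbon. In words, a hydroxy takes the place of a morpholin-4-yl on a carbonyl carbon, turning the amide into a carboxy. Among the compounds with values here, none of the measured compounds carries a carboxy, so the step has to be guessed rather than read from a precedent. The expectation is a step towards a higher number, of a size beyond the scatter, expressed as a 3.2-fold higher number from compound 2 to compound 4 (0.50 log units; beyond the scatter). On that basis compound 4 is estimated at 600 nM in this assay, with a range from 150 nM to 2500 nM.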

Compound 4, half-maximal inhibitory concentration: 17 nM
For compound 4 the middle estimate is 35-fold (1.55 log units) above the measured one; the measured number lies below the stated range.
By their numbers in this assay, from the lowest: compound 4; then compound 3; then compound 2; then compound 1.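

At this carbonyl carbon the morpholin-4-yl is not required for a low number in this assay: hydroxy in its place gives an 11-fold lower number from compound 2 to compound 4 (1.05 log units; beyond the scatter), a large step beyond the scatter. Within the data shown here, the amide thus gives way to a carboxy, and the loss of the whole six-membered ring comes with a lower number, not a higher one; the earlier compounds could not show this, since none of them differ in one place only. Nothing at hand explains the size of this step.

From the compounds shown here alone, it remains open whether the lower number depends on the hydroxy itself or on the absence of the ring, which a primary amide or a methyl ester at this carbonyl carbon could help to separate. Going by these compounds, it is also open whether the same change would give a similar step on the core of compound 1 or compound 3.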